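Swapping an amino side chain for an ether

A few compounds are considered here, and "the series" means these few. Any claim that something is new, unique, unknown or untested is made for them only; others in the source may bear on it.

Compound 2 `CCC(CO)Nc1nc(C)nc2c1nnn2-c1ccc(C(C)C)cc1Br` holds the lowest of the two numbers recorded in an in vitro assay on 293-EBNA cells for binding affinity to corticotropin-releasing factor receptor 1 (Homo sapiens) (on this read-out lower numbers stand for stronger inhibition and higher numbers for weaker inhibition), where compound 2 gives 25.3 nM; compound 1 `COCCCNc1nc(C)nc2c1nnn2-c1ccc(C(C)C)cc1Br` gives 291 nM in this assay. The difference between them is a 12-fold lower number from compound 1 to compound 2 (1.06 log units; beyond the scatter). Compound 3 `CCOCC(COCC)Oc1nc(C)nc2c1nnn2-c1ccc(C(C)C)cc1Br` carries a group of 10 heavy atoms (7 carbon, 3 oxygen; no ring) in place of a group of 6 heavy atoms (4 carbon, 1 nitrogen, 1 oxygen; no ring), on an aromatic carbon. For the measured compounds named here, the only measured step bears on it in reverse: removing one donor from compound 2 gave the large step to compound 1, and compound 3 removes both donors. Compound 3 is therefore expected to give a weaker result, a step of an 18-fold higher number from compound 2 to compound 3 (1.25 log units; beyond the scatter), with an estimate of 450 nM and a range from 80 nM to 2500 nM.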

Compound 3, inhibition constant: 39.7 nM
Compound 3: the middle estimate sits 11-fold (1.05 log units) above what was measured, outside the stated range (below it).
By their numbers in this assay, from the lowest: compounds 2 and 3 (each within the scatter of the next); then compound 1.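

A side chain with 0 hydrogen-bond donors can work on this aromatic carbon: in this assay the change is a 1.6-fold higher number from compound 2 to compound 3 (0.20 log units; within the scatter). The same group also compares well with the 3-methoxypropyl amino side chain, with a 7.3-fold lower number from compound 1 to compound 3 (0.87 log units; beyond the scatter), so removing donors does not by itself raise the number across these compounds. Nothing available here explains this result.

As far as these compounds go, it remains open which part of the new group matters, the linking oxygen or the branched chain. An amine nitrogen carrying the same ethoxymethyl branches would separate these two features.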